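Restoring an Aryl Group on the Ring Nitrogen

The compounds below may be only part of what the source reports. "The series", "measured", "known", "first", "only" and "open" are said of these compounds alone.

Compound 1, `CCCc1ccc(N2C(=O)NC3(CSC4=C3C(=O)c3ncccc3C4=O)C2=O)cc1`: 1 nM
Compound 2, `O=C1NNC(=O)C2(CSC3=C2C(=O)c2ncccc2C3=O)N1`: 1050 nM
Compound 3, `O=C1NC(=O)C2(CSC3=C2C(=O)c2ncccc2C3=O)N1`: 80 nM

These three compounds were tested in a functional assay on ACHN cells (Homo sapiens) for antiproliferative activity, read by MTT assay, with a stated time of 96 h; a lower number here means a stronger inhibitor, a higher number a weaker inhibitor. Compound 3 has the second highest number of the three: compound 1 lies far lower and compound 2 lies higher, both beyond the scatter. Compound 4, `O=C1C2=C(C(=O)c3ncccc31)C1(CS2)NC(=O)N(c2ccc([N+](=O)[O-])cc2)C1=O`, differs from compound 3 in one place: 4-nitrophenyl in place of hydrogen on an amide-type nitrogen in a ring. Among the compounds with values here, the one measured step that bears on this is an 80-fold higher number from compound 1 to compound 3 (1.90 log units; beyond the scatter), where removing an aryl group from that nitrogen gave a much weaker inhibitor. Within the data shown here, putting an aryl group back, here 4-nitrophenyl rather than 4-propylphenyl, is therefore expected to lower the number, though the size is uncertain because no compound with this group has been measured. Compound 4 is expected to give 5 nM, between 1 nM and 30 nM, a step of a 16-fold lower number from compound 3 to compound 4 (1.20 log units; beyond the scatter).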

Compound 4, half-maximal inhibitory concentration: 100 nM
Compound 4: middle estimate off by 20-fold (1.30 log units), on the low side; the measured number lies above the stated range.
By their numbers in this assay, from the lowest: compound 1; then compounds 3 and 4 (each within the scatter of the next); then compound 2.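

Having an aryl group on this ring nitrogen is not enough for a strong inhibitor: 4-nitrophenyl in place of hydrogen gives a 1.3-fold higher number from compound 3 to compound 4 (0.10 log units; within the scatter) and so leaves the number within the scatter. What sits on the aromatic carbon counts instead, as nitro in place of propyl gives a 100-fold higher number from compound 1 to compound 4 (2.00 log units; beyond the scatter) and so loses nearly all the benefit seen in compound 1. Nothing measured here accounts for this gap.

From the compounds shown here alone, it remains open whether an amine or a longer chain such as butyl on that aromatic carbon would behave like propyl or like nitro.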